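The source may hold more compounds than are shown below. What is called first, only, known or untested is meant among the compounds shown, and "the series" means these compounds.

Compound 1 `CC(=O)N1c2ccccc2CCC1C(=O)Nc1ccccc1O` carries an acetyl group on the ring nitrogen of the shared core. In a functional assay on NUGC-3 cells (Homo sapiens) for cytotoxicity, read by sulforhodamine B assay, with a stated time of 72 h (a higher number here means a weaker inhibitor of growth, a lower number a stronger inhibitor of growth), compound 1 gives 49700 nM, the highest of the two numbers in hand. Within the data shown here, the only comparator is compound 2 `O=C(Nc1cc(C(F)(F)F)cc(C(F)(F)F)c1)C1CCc2ccccc2N1C(=O)c1ccccc1`, which in this assay gives 1680 nM; compound 2 differs from compound 1 in more than one place, so no single step links them, and the two values show only that compound 2 inhibits growth more strongly, by a gap beyond the scatter.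

Compound 3 `O=C(Nc1ccccc1O)C1CCc2ccccc2N1C(=O)c1cccc(Cl)c1` is not yet measured. Its change from compound 1 is 3-chlorophenyl in place of methyl on a carbonyl carbon. Among the measured compounds shown here, nothing among the measured compounds isolates this change, as compound 2 also bears a different amide partner. The expectation for compound 3 in this assay is a step downward, beyond the scatter but not reaching the level of compound 2, because compound 2 at 1680 nM combines its ring-nitrogen substituent with that other amide partner. The expected step is a 5.0-fold lower number from compound 1 to compound 3 (0.70 log units; beyond the scatter). Compound 3 is therefore estimated at 10000 nM, with a range from 3000 nM to 30000 nM.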

Compound 3, concentration for 50% growth inhibition: 11000 nM
For compound 3 the middle estimate is 1.1-fold (0.04 log units) below the measured one; the measured number falls inside the stated range.
By their numbers in this assay, from the lowest: compound 2; then compound 3; then compound 1.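

With the amide partner held constant, the series now has its first single-place step: in this assay, going from acetyl to (3-chlorophenyl)carbonyl gives a 4.5-fold lower number from compound 1 to compound 3 (0.65 log units; beyond the scatter). This shows that the position on a carbonyl carbon whose other neighbours are an amide-type nitrogen in a ring accepts 3-chlorophenyl in place of methyl, and that growth inhibition gains from the change, by a modest step. No accompanying measurement bears on this step, which therefore stands as a description of the change and gives no reason for it.

The step brings in the aromatic ring and the chlorine together, so the share of each remains unresolved; benzoyl, cyclohexylcarbonyl or a longer acyl chain such as butanoyl on the amide partner of compound 3 would separate ring, chlorine and size. From the compounds shown here alone, compound 2 differs from compound 3 in more than one place, so the contribution of its bis(trifluoromethyl)phenyl amide partner also stays open, as does whether the gain at the carbonyl position would carry over to that partner.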